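From cyclopentylmethoxy to 2-cyclopentylethoxy in a growth assay

The source may hold more compounds than are shown below. What is called first, only, known or untested is meant among the compounds shown, and "the series" means these compounds.

Measured so far in a functional assay on NCI-H23 cells (Homo sapiens) for antiproliferative activity, read by sulforhodamine B assay; a lower number here means a stronger inhibitor of growth, a higher number a weaker inhibitor of growth
- compound 1 `CC(C)CCCOc1cccc(O)c1C(=O)/C=C/c1ccc(O)cc1` gives 11400 nM
- compound 2 `CC(C)(C)CCOc1cccc(O)c1C(=O)/C=C/c1ccc(C(=O)O)cc1` gives 4770 nM
- compound 3 `O=C(/C=C/c1ccc(O)cc1)c1c(O)cccc1OCC1CCCC1` gives 3160 nM

Compound 3 and compound 2 lie within the usual scatter of repeat measurements of each other, while a 3.6-fold lower number from compound 1 to compound 3 (0.56 log units; beyond the scatter) marks a modest but real gap. The next compound, compound 4 `O=C(/C=C/c1ccc(O)cc1)c1c(O)cccc1OCCC1CCCC1`, differs from compound 3 in one place cyclopentylmethyl in place of cyclopentyl on a saturated chain carbon bound to an oxygen on an aromatic ring on a saturated chain carbon bound to an oxygen on an aromatic ring. Cut one bond further out, the same change reads cyclopentylmethoxy to 2-cyclopentylethoxy.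

Going by the values given here, only one measured step touches this part of the molecule, and a 3.6-fold lower number from compound 1 to compound 3 (0.56 log units; beyond the scatter) is a swap of isopentyl for cyclopentyl, not a lengthening of the same group. It therefore offers only a loose guide, and no shift beyond the scatter is expected in this assay from this small change. The expected size is a 1.1-fold higher number from compound 3 to compound 4 (0.04 log units; within the scatter) and no more. Compound 4 is estimated at 3500 nM with 1400 nM as the expected lower end and 8000 nM as the upper end.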

Compound 4, concentration for 50% growth inhibition: 3370 nM
Compound 4: the middle estimate sits 1.0-fold (0.02 log units) above what was measured, within the range that was stated.
By their numbers in this assay, from the lowest: compounds 3, 4 and 2 (each within the scatter of the next); then compound 1.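

In this assay, moving the cyclopentyl ring one chain carbon further out, from cyclopentylmethoxy to 2-cyclopentylethoxy, leaves growth inhibition essentially unchanged, with a 1.1-fold higher number from compound 3 to compound 4 (0.03 log units; within the scatter). The lengthened group also keeps the gap over the open-chain ether of compound 1, with a 3.4-fold lower number from compound 1 to compound 4 (0.53 log units; beyond the scatter), so the difference first seen as a 3.6-fold lower number from compound 1 to compound 3 (0.56 log units; beyond the scatter) holds for both ring-bearing chains. Nothing available explains why the extra carbon makes so little difference or why the ring-bearing chains differ from the open chain.

Going by these compounds, it remains open whether a still longer chain such as 3-cyclopentylpropoxy, a cyclohexyl ring or an amine on the chain would hold this level of growth inhibition. Compound 2 differs from compound 4 in more than one place, so it says nothing about this chain alone.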